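The compounds below may be only part of what the source reports. "The series", "measured", "known", "first", "only" and "open" are said of these compounds alone.

Of the compounds shown here, three sharing one core have been measured in a functional assay on HT-29 cells (Homo sapiens) for antiproliferative activity, read by sulforhodamine B assay, with a stated time of 48 h; on this read-out higher numbers stand for weaker inhibition and lower numbers for stronger inhibition. Compound 1 `O=C1NCCN1c1ccc(S(=O)(=O)Nc2ccc3[nH]ccc3c2)cc1` gives 130 nM and compound 2 `Cc1cccc(NS(=O)(=O)c2ccc(N3CCNC3=O)cc2)c1` gives 110 nM, two values within the usual scatter of each other. Compound 3 `Cc1ccc(NS(=O)(=O)c2ccc(N3CCNC3=O)cc2)cc1` gives 480 nM, the highest of the three numbers and so the weakest inhibition in this small set.

The next compound, compound 4 `O=C1NCCN1c1ccc(S(=O)(=O)Nc2ccc(I)cc2)cc1`, keeps everything in compound 3 except one group: iodo in place of methyl on an aromatic carbon. Put another way, 4-methylphenyl becomes 4-iodophenyl.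

Going by the values given here, no measured pair makes this swap directly. Among the compounds with values here, the nearest evidence is the one step that only relocates the methyl group, and that step is modest but beyond the scatter: a 4.4-fold higher number from compound 2 to compound 3 (0.64 log units; beyond the scatter). It shows that a small change on this ring can move the number, but it gives no direction for iodo. With no direction supported, the expectation in this assay is no step beyond the scatter, and the expected change is small: a 1.2-fold lower number from compound 3 to compound 4 (0.08 log units; within the scatter). Compound 4 is estimated at 400 nM, with an expected range from 130 nM to 1200 nM.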

Compound 4, half-maximal inhibitory concentration: 650 nM
Estimate against measurement, compound 4: 1.6-fold (0.21 log units) below; the range from low to high includes it.
By their numbers in this assay, from the lowest: compounds 2 and 1 (each within the scatter of the next); then compounds 3 and 4 (each within the scatter of the next).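

In this assay, iodo in place of methyl on this aromatic carbon, para to a large group, gives a 1.4-fold higher number from compound 3 to compound 4 (0.13 log units; within the scatter), so this assay does not tell the two groups apart at this position. Going by these compounds alone, the earlier compounds showed only that moving a methyl group could shift the number; this pair shows that replacing that methyl with a different single heavy atom, here iodine, need not shift it beyond the scatter. Set against the 3-methylphenyl of compound 2, the new compound shows a 5.9-fold higher number from compound 2 to compound 4 (0.77 log units; beyond the scatter), so among compound 2, compound 3 and compound 4, both 4-substituted compounds lie beyond the scatter from compound 2, though this rests on just these two groups. Nothing in the data explains this result.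

On these data alone, it remains open whether this insensitivity extends to other groups at this position, such as an amine, a carboxylic acid or a longer alkyl chain. As far as these compounds go, it is also open whether iodo placed where compound 2 carries its methyl would match that compound's number.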